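A few compounds are considered here, and "the series" means these few. Any claim that something is new, unique, unknown or untested is made for them only; others in the source may bear on it.

Working notes on two measured spiropiperidine amides and one analogue still to be tested in an assay on HEK293 cells for antagonist activity at growth hormone secretagogue receptor type 1 (Homo sapiens); a lower number here means a stronger inhibitor, a higher number a weaker inhibitor.

Compound 1 `COc1ccc(OCC(=O)N2CCC3(CC2)CN(Cc2ccc(OCC(C)C)cc2Cl)C3)cc1` gives 20 nM in this assay. Compound 2 `COc1ccc(OCC(=O)N2CCC3(CC2)CN(Cc2ccc(-n4nccn4)cc2)C3)cc1` gives 14 nM in this assay; the two numbers lie within the usual scatter, so no order between them can be read from them.

Compound 3 `COc1ccc(OCC(=O)N2CCC3(CC2)CN(Cc2ccc(-n4nccn4)cc2Cl)C3)cc1` carries the change chloro in place of hydrogen on an aromatic carbon relative to compound 2. Among the compounds with values here, no measured pair shows this change in isolation, and compound 1 bears a chloro group in a different setting, so the size of the step is not established. The expected step from compound 2 to compound 3 is a 1.2-fold lower number from compound 2 to compound 3 (0.07 log units; within the scatter), that is, none beyond the scatter. For compound 3 the estimate in this assay is 12 nM, with a range from 5 nM to 30 nM.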

Compound 3, inhibition constant: 11 nM
Estimate against measurement, compound 3: 1.1-fold (0.04 log units) above; measured number inside the range.
By their numbers in this assay, from the lowest: compounds 3, 2 and 1 (each within the scatter of the next).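

In this assay, chloro in place of hydrogen at this position, ortho to a large group and meta to the 2H-1,2,3-triazol-2-yl group, now stands as a measured pair: a 1.3-fold lower number from compound 2 to compound 3 (0.10 log units; within the scatter) shows that the aromatic carbon takes chloro with no step beyond the scatter. With chloro present in both compounds, 2H-1,2,3-triazol-2-yl in place of isobutoxy gives a 1.8-fold lower number from compound 1 to compound 3 (0.26 log units; within the scatter) and does not separate the two groups. No supporting data bear on these results.

Still open, from the compounds shown here alone, is whether a fluoro or methoxy group at this position would give a step beyond the scatter. The same holds for an amine or a carboxylic acid in place of the 2H-1,2,3-triazol-2-yl group.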